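Bis-arylidene series on the shared core: cytotoxicity notes

The source may hold more compounds than are shown below. What is called first, only, known or untested is meant among the compounds shown, and "the series" means these compounds.

Measured so far:
compound 1 `C=CCn1c(=O)/c(=C\c2cc(F)ccc2C)[nH]c(=O)/c1=C\c1ccccc1OC` gives 2600 nM
compound 2 `C=CCn1c(=O)/c(=C\c2cccc(Br)c2)[nH]c(=O)/c1=C\c1ccccc1OC` gives 5200 nM

In a functional assay on HL-60 cells (Homo sapiens) for cytotoxicity, read by CCK-8 assay, with a stated time of 72 h (on this read-out lower numbers stand for stronger inhibition and higher numbers for weaker inhibition), compound 2 has the highest of the two numbers; its nearest neighbour is compound 1, and the step of a 2.0-fold higher number from compound 1 to compound 2 (0.30 log units; within the scatter) is within the scatter. Compound 3 `C=CCn1c(=O)/c(=C\c2cccc(Br)c2)[nH]c(=O)/c1=C\c1cccc(Br)c1` is not yet measured. It differs from compound 2 by 3-bromophenyl in place of 2-methoxyphenyl on a double-bonded chain carbon bound to an aromatic carbon. Among the measured compounds shown here, no measured step touches this group; the only step known, from compound 1 to compound 2, exchanged the other aryl and moved the number by less than the scatter. Compound 3 is therefore expected to lie near compound 2, with a step of a 1.2-fold higher number from compound 2 to compound 3 (0.06 log units; within the scatter) expected. The estimate for compound 3 is 6000 nM, range 2500 nM to 15000 nM.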

Compound 3, half-maximal inhibitory concentration: "not active" (no number reported)
No number was reported for compound 3, and the estimate cannot be compared.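

Among the compounds shown here, compound 3 is reported as "not active" in this assay with no number, so no step from compound 2 can be read. No other data bear on this result.
The compounds shown leave open how far 3-bromophenyl in place of 2-methoxyphenyl moves the number.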